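The compounds below may be only part of what the source reports. "The series", "measured", "known", "first", "only" and "open" are said of these compounds alone.

Three compounds have so far been examined in an ADME assay on PC-3 cells (Homo sapiens) for cytotoxicity, read by WST assay, tested at 100 uM; on this read-out lower numbers stand for less inhibition and higher numbers for more inhibition at the one concentration tested (going by the name of the read-out). Compound 1 `O=C(Nc1cccc(Cc2ccccc2)c1)C1CCCN(C(=O)c2cc(C(F)(F)F)cc(C(F)(F)F)c2)C1` gives 0% in this assay. Compound 2 `O=C(Nc1cccc(Oc2ccccc2)c1)C1CCCN(C(=O)c2cccc(-c3ccco3)c2)C1` gives 0%, and compound 3 `Cc1nc(-c2cccc(C(=O)N3CCCC(C(=O)Nc4ccc(Cl)cc4)C3)c2)no1` gives 0%. On these numbers compound 1 stands level with compounds 2 and 3 at the digits reported; compound 2 is the nearest and compound 3 the furthest, and in neither case is there any change beyond the usual scatter.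

Compound 4 `CSc1cccc(NC(=O)C2CCCN(C(=O)c3cc(C(F)(F)F)cc(C(F)(F)F)c3)C2)c1` has not yet been measured. It differs from compound 1 in one place: methylsulfanyl in place of benzyl on an aromatic carbon. For the measured compounds named here, no pair of measured compounds that differ in a single place is available, so there is no direct precedent for a change of this kind on the shared core. Compound 1 gives 0%, and compounds 2 and 3 likewise show no inhibition at the concentration tested. The step from compound 1 to compound 4 is therefore expected to be a number 2 percentage points higher from compound 1 to compound 4 (within the scatter), none beyond the scatter. Compound 4 is estimated to give 2% in this assay, within a range from 0% to 12%.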

Compound 4, a percentage reported as inhibition, at one concentration (the size of the read-out at that concentration, not a potency): 0%
Compound 4: the middle estimate sits 2 percentage points above what was measured; measured number inside the range.
By their numbers in this assay, from the lowest: compounds 1, 2, 3 and 4 (each within the scatter of the next).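

In this assay methylsulfanyl in place of benzyl on an aromatic carbon, meta to a large group, gives no change at the digits printed from compound 1 to compound 4 (within the scatter). For the compounds shown here, this is the first pair in the set that differs in a single place, and it shows that at this position the benzyl group, with its six-membered aromatic ring, can give way to the much smaller methylsulfanyl without any inhibition appearing in this read-out. Nothing available bears on the reason for this result.

The compounds shown leave open whether any other group at this position would move the read-out at all, since an amine, a carboxylic acid or a longer alkyl chain is not among them. Going by these compounds alone, with no single-place step yet showing a difference, they also leave open which part of the shared core, if any, can change this number.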